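The source may hold more compounds than are shown below. What is called first, only, known or untested is meant among the compounds shown, and "the series" means these compounds.

Compound 1 `COC(=O)c1c[nH]c2cc(OCCOc3ccccc3)c(OC)cc2c1=O`: > 20000 nM (a limit)
Compound 2 `COC(=O)c1c[nH]c2cc(OCCOc3ccccc3)c(Cl)cc2c1=O`: > 20000 nM (a limit)

Both entries come from an ADME assay on J774 cells (Mus musculus) for cytotoxicity; on this read-out lower numbers stand for an effect already at smaller amounts and higher numbers for an effect only at larger amounts of compound. Compound 2 stands on a limit of the assay, > 20000 nM, and not on a number. Its position is shared with compound 1, as the limit of > 20000 nM in this assay, at which 2 of the 2 values shown sit, shows. Compound 3 `COC(=O)c1c[nH]c2cc(OCCOc3ccccc3)c(C)cc2c1=O` follows from compound 2 by one change, methyl in place of chloro on an aromatic carbon. For the measured compounds named here, the only measured step that bears on this is a step that the two limits leave unreadable from compound 1 to compound 2, which also changes the group on that carbon, and it has no readable size. With no measured size to carry over, no step beyond the scatter is expected in this assay, and no direction can be argued. The expected step is a number no higher from compound 2 to compound 3 (the limit leaves the size open). For compound 3 the estimated value is 20000 nM, with an expected range from 10000 nM to 40000 nM.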

Compound 3, half-maximal effective concentration: > 20000 nM
Compound 3: no number, only a limit; the forecaster's own chance of this, stated with the estimate: 85%; the middle value lies on the limit itself.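

In this assay compound 3 gives > 20000 nM as a limit, not a number. For the compounds shown here, compound 1, compound 2 and compound 3 all stand on limits, so no step among them can be read. Left open is how these three compare, and at what concentration any of them would reach a half-maximal effect.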